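From Methoxy to Propylsulfonyl: Expected Cytotoxicity of Compound 3

The source may report more compounds than this note shows. Statements on the series, on what has been measured and on what is new or still open speak of the compounds shown alone.

Measured compounds:
compound 1 `CNC(=O)c1ncn(-c2ncc(OC)c3c(C(=O)C(=O)N4CCN(C(=O)c5ccccc5)CC4)c[nH]c23)n1` — > 300000 nM
compound 2 `COc1ncn(-c2ncc(OC)c3c(C(=O)C(=O)N4CCN(C(=O)c5ccccc5)CC4)c[nH]c23)n1` — 285000 nM

In a functional assay on MT2 cells (Homo sapiens) for cytotoxicity, read by XTT assay, with a stated time of 3 days (a higher number here means that more compound is tolerated, a lower number that less compound is tolerated), compound 1 gives > 300000 nM, which is a limit of the assay rather than a number (the limit of > 300000 nM in this assay, at which 1 of the 2 values shown sits). Compound 2 gives 285000 nM, the only actual number shown. The step of an at least 1.0-fold lower number from compound 1 to compound 2 (0.02 log units; that floor lies within the scatter) lies within the scatter. Compound 3 `CCCS(=O)(=O)c1ncn(-c2ncc(OC)c3c(C(=O)C(=O)N4CCN(C(=O)c5ccccc5)CC4)c[nH]c23)n1` differs from compound 2 by propylsulfonyl in place of methoxy on an aromatic carbon. For the measured compounds named here, only one measured step exists, an at least 1.0-fold lower number from compound 1 to compound 2 (0.02 log units; that floor lies within the scatter), and it did not move the value beyond the scatter. The author expects no step beyond the scatter, a 1.1-fold lower number from compound 2 to compound 3 (0.06 log units; within the scatter). Compound 3 is estimated at 250000 nM, between 100000 nM and 500000 nM.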

Compound 3, half-maximal cytotoxic concentration: 207000 nM
Beside the measured number, compound 3's estimate is 1.2-fold (0.08 log units) above it, within the range that was stated.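

In this assay, the aromatic carbon between two ring nitrogen atoms now carries propylsulfonyl, with 6 heavy atoms in place of the 2 of methoxy, and the swap gives a 1.4-fold lower number from compound 2 to compound 3 (0.14 log units; within the scatter). Set against methylcarbamoyl at the same carbon, propylsulfonyl gives an at least 1.4-fold lower number from compound 1 to compound 3 (0.16 log units; that floor lies within the scatter). Compound 1 remains a limit rather than a number: the limit of > 300000 nM in this assay, at which 1 of the 3 values shown sits.

From the compounds shown here alone, whether an amine or a carboxylic acid at this carbon would stay within the scatter remains open. So does the outcome for an alkylsulfonyl chain longer than propyl.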